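Extending the ring on the aromatic nitrogen of compound 3

This account rests on a few compounds, and the source may have more. Where it says the series, first, only, none or still open, it means among the compounds named here.

Compound 3 `Nc1ncnc2c1c(Oc1cc(C(F)(F)F)ccn1)nn2C1CCC1` is measured in an ADME assay on microsomes from liver (Mus musculus) for metabolic stability, read by LC-MS, using NADPH, with a stated time of 10 min, tested at 10 uM (a lower number here means that the compound disappears faster, a higher number that the compound lasts longer), at 0.128 h. Among the three compounds shown it gives the lowest number, yet its gap to compound 2 `CO[C@H]1CC[C@H](n2nc(Oc3cc(C(F)(F)F)ccn3)c3c(N)ncnc32)CC1`, at 0.217 h, is within the scatter, while compound 1 `N#Cc1ccnc(Oc2nn(C3CCC3)c3ncnc(N)c23)c1`, at 0.4 h, lies beyond it. Compound 4 `Nc1ncnc2c1c(Oc1cc(C(F)(F)F)ccn1)nn2[C@H]1CC[C@@H](CO)CC1` differs from compound 3 by 4-(hydroxymethyl)cyclohexyl in place of cyclobutyl on an aromatic nitrogen. For the measured compounds named here, the only step that bears on this is a 1.7-fold lower number from compound 2 to compound 3 (0.23 log units; within the scatter), which points in the opposite direction and was within the scatter. A return toward a six-membered ring on that nitrogen is therefore expected to give a 1.6-fold higher number from compound 3 to compound 4 (0.19 log units; within the scatter), a shift in this assay that should stay within the usual scatter. Compound 4 is estimated at 0.2 h, with a range from 0.1 h to 0.45 h.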

Compound 4, half-life: 0.108 h
Compound 4: middle estimate off by 1.9-fold (0.27 log units), on the high side; the range from low to high includes it.
By their numbers in this assay, from the lowest: compounds 4, 3, 2 and 1 (each within the scatter of the next, the first and the last beyond it).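

In this assay, 4-(hydroxymethyl)cyclohexyl in place of cyclobutyl on the aromatic nitrogen gives a 1.2-fold lower number from compound 3 to compound 4 (0.07 log units; within the scatter) and so does not set the six-membered ring with its hydrogen-bond donor apart from the four-membered ring. The same group in place of 4-methoxycyclohexyl gives a 2.0-fold lower number from compound 2 to compound 4 (0.30 log units; within the scatter) and so does not separate these two six-membered substituents either. Nothing available explains these results. From the compounds shown here alone, whether an amine or a carboxylic acid on the cyclohexyl ring would move the half-life beyond the scatter remains open.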